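The source may hold more compounds than are shown below. What is called first, only, known or untested is meant among the compounds shown, and "the series" means these compounds.

Compound 1 `Nc1ccc2cccc(OCCC3CC3)c2n1` gives 492 nM in an assay on cells with melanin-concentrating hormone receptor 1 (Homo sapiens) as the target, read by radioligand binding; on this read-out higher numbers stand for weaker inhibition and lower numbers for stronger inhibition. Compound 2 `CSCCOc1cccc2ccc(N)nc12` reaches only a limit of the assay, > 2000 nM. Within the data shown here, the one measured step, an at least 4.0-fold higher number from compound 1 to compound 2 (0.60 log units; beyond the scatter), therefore marks compound 2 as the weaker of the two, and the limit of > 2000 nM in this assay, at which 1 of the 2 values shown sits, describes where it stands. Compound 3 `Nc1ccc2cccc(OCC3CCOC3)c2n1` differs from compound 2 by oxolan-3-yl in place of (methylsulfanyl)methyl on a saturated chain carbon bound to an oxygen on an aromatic ring. Because the cyclopropyl of compound 1 gave the lower number in an at least 4.0-fold higher number from compound 1 to compound 2 (0.60 log units; beyond the scatter), bringing a ring back could undo part of that step, though the limit on compound 2 leaves the size uncertain. Compound 3 is expected at 800 nM, within 300 nM to 2500 nM. The expected step is an at least 2.5-fold lower number from compound 2 to compound 3 (0.39 log units; beyond the scatter).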

Compound 3, half-maximal inhibitory concentration: 115 nM
Compound 3: the middle estimate sits 7.0-fold (0.84 log units) above what was measured; measured number below the stated range.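

Replacing (methylsulfanyl)methyl with oxolan-3-yl at this chain carbon gives an at least 17-fold lower number from compound 2 to compound 3 (1.24 log units; beyond the scatter), a large change in the side chain's effect. Compound 2 is known only as an assay limit: the limit of > 2000 nM in this assay, at which 1 of the 3 values shown sits. Oxolan-3-yl in place of cyclopropylmethyl also gives a 4.3-fold lower number from compound 1 to compound 3 (0.63 log units; beyond the scatter), so these two ring-bearing chains differ clearly and the presence of a ring alone does not set the value.

Whether the ring oxygen or the ring size accounts for this difference stays open. A cyclopentyl ring or a tetrahydropyran-4-yl ring at the same place would separate the two.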